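The compounds below may be only part of what the source reports. "The series", "measured", "known", "first", "only" and "open" are said of these compounds alone.

Series notes. In a functional assay on MCF7 cells (Homo sapiens) for cytotoxicity, read by CCK-8 assay, with a stated time of 72 h (on this read-out higher numbers stand for weaker inhibition and lower numbers for stronger inhibition), compound 1 `C=CCn1c(=O)/c(=C\c2ccccc2OC)[nH]c(=O)/c1=C\c1ccccc1OC` gives 41100 nM and compound 2 `C=CCn1c(=O)/c(=C\c2ccccc2C(F)(F)F)[nH]c(=O)/c1=C\c1ccccc1OC` gives 6500 nM; the step of a 6.3-fold lower number from compound 1 to compound 2 (0.80 log units; beyond the scatter) is the only measured one. Compound 3 `COc1ccccc1/C=c1/[nH]c(=O)/c(=C\c2cccc(Cl)c2Cl)[nH]c1=O` in this assay is reported as "not active" (no number reported), so no single number places it among the others. Compound 4 `C=CCn1c(=O)/c(=C\c2cccc(Cl)c2Cl)[nH]c(=O)/c1=C\c1ccccc1OC` differs from compound 3 by allyl in place of hydrogen on an aromatic nitrogen. Among the compounds with values here, no measured step covers that change: the step from compound 1 to compound 2 concerns a substituent on an aromatic carbon, and compounds 1 and 2 both already carry the allyl group. Within the data shown here, with compound 3 inactive and no step to scale from, compound 4 is expected to stay weak, an estimated 20000 nM in this assay, within 4000 nM to 100000 nM, with a fair chance that only inactivity is reported again.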

Compound 4, half-maximal inhibitory concentration: 2100 nM
For compound 4 the middle estimate is 9.5-fold (0.98 log units) above the measured one; measured number outside the range, below it.
By their numbers in this assay, from the lowest: compound 4; then compound 2; then compound 1.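

In this assay the aryl group on the double-bonded chain carbon still has room to move the number, with a 3.1-fold lower number from compound 2 to compound 4 (0.49 log units; beyond the scatter) and a 20-fold lower number from compound 1 to compound 4 (1.29 log units; beyond the scatter) making 2,3-dichlorophenyl the lowest of the three compounds with numbers. With allyl on the aromatic nitrogen compound 4 gives a number, whereas compound 3, with hydrogen there, is reported as not active, so this pair shows a direction but no readable size. No supporting data on the cause of either change are available.

Open, going by these compounds, is whether a longer chain or a carboxylic acid in place of allyl would retain this activity. Also open, on these data alone, is whether allyl has the same effect alongside the other aryl groups.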